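The source may hold more compounds than are shown below. What is called first, only, known or untested is meant among the compounds shown, and "the series" means these compounds.

Compound 1 `Cn1cc(/C=C/C(=O)O)cc1Cn1ccnc1` and compound 2 `Cn1c(/C=C/C(=O)O)ccc1Cn1ccnc1` carry the same groups on the same core, arranged differently. In a functional assay on microsomes from aorta for inhibition of Thromboxane-A synthase (Homo sapiens), in the presence of a further agent that is not named here (a higher number here means a weaker inhibitor, a lower number a stronger inhibitor), compound 1 gives 4600 nM. In this assay compound 2 gives 3800 nM, and since the gap to compound 1 falls within the usual scatter of repeated measurements, the two numbers cannot be told apart and neither compound can be called the stronger inhibitor. Compound 3 `C/C(=C/c1ccc(Cn2ccnc2)n1C)C(=O)O` has not yet been measured. It differs from compound 2 in one place: 2-carboxyprop-1-en-1-yl in place of 2-carboxyethenyl on an aromatic carbon. Within the data shown here, no measured pair shows what such a change does, so the expectation rests only on the small size of the change. The expected step is a 1.1-fold higher number from compound 2 to compound 3 (0.02 log units; within the scatter), that is, nothing beyond the scatter in either direction. Compound 3 is therefore estimated at 4000 nM in this assay, within a range from 1500 nM to 11000 nM.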

Compound 3, half-maximal inhibitory concentration: 1000 nM
Compound 3: middle estimate off by 4.0-fold (0.60 log units), on the high side; the whole stated range lies above it.
By their numbers in this assay, from the lowest: compound 3; then compounds 2 and 1 (each within the scatter of the next).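

In this assay, putting 2-carboxyprop-1-en-1-yl in place of 2-carboxyethenyl gives a 3.8-fold lower number from compound 2 to compound 3 (0.58 log units; beyond the scatter), so compound 3 is a stronger inhibitor than compound 2. This shows that the group at this position affects the read-out, even though the change only takes it from 5 heavy atoms to 6 and leaves the counts of hydrogen-bond donors and acceptors the same. Nothing available here explains why this small change has an effect of this size.

The compounds shown leave open whether the same change would also give a lower number on the arrangement of compound 1. They also leave open how a longer chain on the same double bond, or an amide in place of the carboxylic acid, would behave.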